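A few compounds are considered here, and "the series" means these few. Any claim that something is new, unique, unknown or untested is made for them only; others in the source may bear on it.

Compound 1 `COc1cc(Cl)cc(-c2nn(-c3cccc(NC(=O)Nc4ccc(Cl)c(C(F)(F)F)c4)c3)cc2-c2ccncc2)c1` gives -15% in a functional assay on NCI/ADR-RES cells (Homo sapiens) for inhibition, read by sulforhodamine B assay, with a stated time of 48 h, tested at 100 uM (on this read-out higher numbers stand for a weaker effect at the one concentration tested and lower numbers for a stronger effect), the lowest of the two numbers measured. Compound 2 `COc1cc(Cl)cc(-c2nn(-c3cccc(NC(=O)c4cccc(C(F)(F)F)c4)c3)cc2-c2ccncc2)c1` gives 31% in this assay. That step, a number 46 percentage points higher from compound 1 to compound 2 (beyond the scatter), is large. Compound 3 `O=C(Nc1cccc(-n2cc(-c3ccncc3)c(-c3cc(O)cc(Cl)c3)n2)c1)Nc1ccc(Cl)c(C(F)(F)F)c1` differs from compound 1 at another place: hydrogen in place of methyl on an oxygen on an aromatic ring. For the measured compounds named here, no measured step touches this oxygen: the single step known, from compound 1 to compound 2, alters the group on the carbonyl carbon and says nothing about the methyl on the oxygen. The step of a number 10 percentage points higher from compound 1 to compound 3 (within the scatter) is therefore expected to be small, possibly within the scatter. Compound 3 is estimated at -5% in this assay, between -35% and 30%.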

Compound 3, a percentage reported as activity, at one concentration (the size of the read-out at that concentration, not a potency): -15%
Compound 3: middle estimate off by 10 percentage points, on the high side; low and high end bracket the measured number.
By their numbers in this assay, from the lowest: compounds 1 and 3 (each within the scatter of the next); then compound 2.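

In this assay, exchanging methoxy for hydroxy on the 3-chloro-5-methoxyphenyl group gives no change at the digits printed from compound 1 to compound 3 (within the scatter), so removing this methyl leaves the read-out unchanged while the rest of compound 1 stays in place. This shows that the read-out at this oxygen does not depend on the methyl, a point the earlier step at the carbonyl carbon could not address. No evidence available here accounts for this result. Still open, from the compounds shown here alone, is whether an ethoxy group, a longer chain on this oxygen or an amine in its place would behave alike, and whether hydroxy would give the same result alongside the 3-(trifluoromethyl)phenyl group of compound 2.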